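Swapping a Fluoro for a Methoxy on the Aryl Ring

The compounds below may be only part of what the source reports. "The series", "measured", "known", "first", "only" and "open" are said of these compounds alone.

Of the compounds shown here, three have been tested in a functional assay on the whole organism (Central nervous system) with Mus musculus as the target; a higher number here means that more compound is needed for the effect, a lower number that less compound is needed. Compound 1 (`O=C(CCC(=O)c1cccs1)NCCCO`) gives 300 mg/kg in this assay. Compound 2 (`O=C(CCC(=O)c1ccc(F)cc1)NCCCO`) gives 500 mg/kg. Compound 3 (`Cc1ccc(C23CCC(=O)N2CCCO3)cc1`) gives 160 mg/kg. Among these three, compound 2 holds the top number, but its gap to compound 1 lies within the usual scatter of repeated measurements, so the two cannot be told apart; only the gap to compound 3 lies beyond the scatter.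

Compound 4 (`COc1ccc(C(=O)CCC(=O)NCCCO)cc1`) has not yet been measured. It differs from compound 2 in one place: methoxy in place of fluoro on an aromatic carbon. For the measured compounds named here, none of the measured compounds show what such a swap does in this assay, so there is no measured step to lean on. With nothing to point either way, the expectation is that the step from compound 2 to compound 4 stays within the scatter, that is a 1.3-fold lower number from compound 2 to compound 4 (0.10 log units; within the scatter), with no clear direction.

On that basis compound 4 is expected to give about 400 mg/kg in this assay, with a range from 200 mg/kg to 800 mg/kg.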

Compound 4, dose for half-maximal effect: 800 mg/kg
The estimate for compound 4 lay 2.0-fold (0.30 log units) below the measured number, and the stated range covers the measured number.
By their numbers in this assay, from the lowest: compounds 3, 1, 2 and 4 (each within the scatter of the next, the first and the last beyond it).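

Putting methoxy in place of fluoro on this aromatic carbon, para to a large group, gives a 1.6-fold higher number from compound 2 to compound 4 (0.20 log units; within the scatter) in this assay. For the compounds shown here, this is the first measured swap at this position, and it shows that exchanging a single fluorine for a methoxy group, which brings one more heavy atom and a hydrogen-bond acceptor, leaves compound 2 and compound 4 indistinguishable in this whole-animal test. Nothing available explains this outcome or links it to any particular property of either group.

Going by these compounds alone, whether a different group at the same position, such as an ethoxy group, an amine or a carboxylic acid, would produce a step beyond the scatter remains open, since fluoro and methoxy are the only two groups compared here. A single pair also cannot show whether the same swap would give a similar step in a compound with a different core or side chain, so this result applies only to compound 2 and compound 4.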